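Fluoro to trifluoromethyl on the shared core

The compounds below may be only part of what the source reports. "The series", "measured", "known", "first", "only" and "open" are said of these compounds alone.

Measured so far:
compound 1 `Oc1cccc(-c2cc(-c3ccccc3F)cc(-c3cccc(O)c3)n2)c1` 4370 nM
compound 2 `Oc1ccc(-c2cc(-c3ccccc3F)cc(-c3cccc(O)c3)n2)cc1` 6370 nM

Among the measured compounds shown here, in a functional assay on T47D cells (Homo sapiens) for inhibition (on this read-out lower numbers stand for stronger inhibition and higher numbers for weaker inhibition), compound 1 gives the lowest of the two numbers; the only neighbour, compound 2, lies a 1.5-fold higher number from compound 1 to compound 2 (0.16 log units; within the scatter). Compound 3 `Oc1cccc(-c2cc(-c3ccccc3C(F)(F)F)cc(-c3cccc(O)c3)n2)c1` differs from compound 1 in one place: trifluoromethyl in place of fluoro on an aromatic carbon. For the measured compounds named here, no measured step touches that site; the single known step concerns the hydroxyphenyl arrangement and stays within the scatter. There is therefore no basis for expecting a shift beyond the scatter in this assay. Compound 3 is expected to give about 4000 nM, with a wide range of 1000 nM to 16000 nM, which means an estimated step of a 1.1-fold lower number from compound 1 to compound 3 (0.04 log units; within the scatter).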

Compound 3, half-maximal inhibitory concentration: 4350 nM
Compound 3: middle estimate off by 1.1-fold (0.04 log units), on the low side, within the range that was stated.
By their numbers in this assay, from the lowest: compounds 3, 1 and 2 (each within the scatter of the next).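

The step from 2-fluorophenyl to 2-(trifluoromethyl)phenyl gives a 1.0-fold lower number from compound 1 to compound 3 (0.00 log units; within the scatter) in this assay on the shared core. This position, ortho to a large group, therefore accepts the larger trifluoromethyl in place of fluoro with no difference beyond the scatter, whereas the earlier step concerned only the hydroxyphenyl arrangement. No available measurement accounts for this result.

Going by these compounds, whether an amine, a carboxylic acid or a methoxy group at this position would leave the read-out equally unmoved remains open. Also open, on these data alone, is whether trifluoromethyl behaves the same way with the 4-hydroxyphenyl arrangement of compound 2.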